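A Dimethyl Sulfonamide on a Longer Chain

The compounds below may be only part of what the source reports. "The series", "measured", "known", "first", "only" and "open" are said of these compounds alone.

Compound 1, `NS(=O)(=O)CCNc1nonc1/C(=N/O)Nc1ccc(F)c(Br)c1`: 11 nM
Compound 2, `O=S(=O)(CCNc1nonc1/C(=N/O)Nc1ccc(F)c(Br)c1)NO`: > 800 nM

In an assay on HeLa cells for inhibition of Indoleamine 2,3-dioxygenase 1 (Homo sapiens), read by spectrophotometry, with a stated time of 24 h (on this read-out lower numbers stand for an effect already at smaller amounts and higher numbers for an effect only at larger amounts of compound), compound 1 gives 11 nM, the only number shown in this assay. For compound 2 this assay reports a limit rather than a number, > 800 nM. The other value shown is thus (the limit of > 800 nM in this assay, at which 1 of the 2 values shown sits). Among the measured compounds shown here, the one measured step, an at least 72-fold higher number from compound 1 to compound 2 (1.86 log units; beyond the scatter), shows that touching the sulfonamide nitrogen of compound 1 can cost a great deal in this assay.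

Compound 3, `CN(C)S(=O)(=O)CCCNc1nonc1/C(=N/O)Nc1ccc(F)c(Br)c1`, is not yet measured. It differs from compound 1 in one place: (dimethylsulfamoyl)methyl in place of sulfamoyl on a saturated chain carbon, two bonds along the chain from a nitrogen on an aromatic ring. Two things change at once here: the sulfonamide nitrogen carries two methyl groups instead of hydrogens, and the chain to that sulfonamide grows by one carbon. For the measured compounds named here, only the step from compound 1 to compound 2 bears on this, and it was large, though its change, a hydroxy on the sulfonamide nitrogen, is not the same as methylation. A loss in this assay is therefore expected for compound 3, smaller than that seen for compound 2, at a 5.5-fold higher number from compound 1 to compound 3 (0.74 log units; beyond the scatter). The estimate for compound 3 in this assay is 60 nM, with a range from 15 nM to 300 nM.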

Compound 3, half-maximal effective concentration: 20 nM
For compound 3 the middle estimate is 3.0-fold (0.48 log units) above the measured one, within the range that was stated.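

In this assay, the sulfonamide end of the chain proves open to a substantial change, as the 3-(dimethylsulfamoyl)propyl chain of compound 3 replaces the 2-sulfamoylethyl chain of compound 1 with a 1.8-fold higher number from compound 1 to compound 3 (0.26 log units; within the scatter). Substitution on the sulfonamide nitrogen therefore does not in itself carry the cost seen with hydroxy, and the hydrogen-bond donor of the sulfamoyl group can be absent without a change beyond the scatter, as the separation between the two substituted compounds shows: an at least 40-fold lower number from compound 2 to compound 3 (1.60 log units; beyond the scatter). Compound 2 is reported only as a limit, so this separation is a bound and not an exact size: the limit of > 800 nM in this assay, at which 1 of the 3 values shown sits.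

The two methyl groups and the extra chain carbon arrive in a single step, so the compounds shown cannot say what either contributes alone, or whether one offsets the other. Also open, on these data alone, is how far this end of the chain can be pushed, for example with a morpholine sulfonamide, a still longer chain, or a carboxylic acid in place of the sulfonamide.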